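Methoxy to Hydroxy on a Shared Core

A few compounds are considered here, and "the series" means these few. Any claim that something is new, unique, unknown or untested is made for them only; others in the source may bear on it.

In a functional assay on NCI-H322M cells (Homo sapiens) for inhibition, read by sulforhodamine B assay, with a stated time of 48 h (on this read-out lower numbers stand for stronger inhibition of growth and higher numbers for weaker inhibition of growth), compound 1 `COc1cc(-c2nn(-c3cccc(NC(=O)c4ccc(Cl)c(C(F)(F)F)c4)c3)cc2-c2ccncc2)ccc1Cl` gives > 32500 nM, a limit of the assay and not a number.
In this assay compound 2 `COc1cc(-c2nn(-c3cccc(NC(=O)Nc4ccc(Cl)c(C(F)(F)F)c4)c3)cc2-c2ccncc2)ccc1Cl` gives 13900 nM.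
In this assay compound 3 `COc1cc(-c2nn(-c3cccc(NC(=O)c4ccccc4)c3)cc2-c2ccncc2)ccc1Cl` gives > 100000 nM, again a limit of the assay.

Compound 2 is thus the only one of the three with a number in this assay. Compound 4 `O=C(Nc1cccc(-n2cc(-c3ccncc3)c(-c3ccc(Cl)c(O)c3)n2)c1)Nc1ccc(Cl)c(C(F)(F)F)c1` differs from it by hydrogen in place of methyl on an oxygen on an aromatic ring. The measured steps, an at least 2.3-fold lower number from compound 1 to compound 2 (0.36 log units; beyond the scatter), an at least 7.1-fold higher number from compound 2 to compound 3 (0.85 log units; beyond the scatter) and a step that the two limits leave unreadable from compound 1 to compound 3, all swap the group on the carbonyl carbon; none touches the oxygen on the aromatic ring, so none bears on this change. The expectation is therefore no step beyond the scatter, a 1.0-fold higher number from compound 2 to compound 4 (0.00 log units; within the scatter). Compound 4 is estimated at 14000 nM, between 4500 nM and 45000 nM.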

Compound 4, concentration for total growth inhibition: 4480 nM
For compound 4 the middle estimate is 3.1-fold (0.49 log units) above the measured one, outside the stated range (below it).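

Replacing methoxy with hydroxy in this assay gives a 3.1-fold lower number from compound 2 to compound 4 (0.49 log units; beyond the scatter). Going by these compounds alone, the earlier steps all changed the group on the carbonyl carbon, so this is the first sign that the group on the oxygen on the aromatic ring also affects growth inhibition. Nothing shown gives a reason for this step.

The compounds shown leave open how a longer chain such as ethoxy, or an amine in place of the hydroxy, would read at this position. They also leave open whether hydroxy would have a similar effect with the amide of compound 1.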